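Swapping the five-membered ring on a dihydropyrimidinone scaffold

The compounds below may be only part of what the source reports. "The series", "measured", "known", "first", "only" and "open" are said of these compounds alone.

Compound 1, `CC1=C(C(=O)C2CC2)C(c2ccsc2)NC(=O)N1`: 2%
Compound 2, `CC1=C(C(=O)OCC2CC2)C(c2ccco2)NC(=O)N1`: 29%

Of the compounds shown here, two sharing one core have been tested in an assay on membranes from CHO cells for displacement of a labelled ligand from adenosine receptor A1 (Homo sapiens), read by scintillation counting, with a stated time of 60 min, tested at 1 uM; a higher number here means more inhibition at the concentration tested (going by the name of the read-out), a lower number less inhibition. In this assay compound 1 gives 2%, while compound 2 gives 29%. Compound 2 thus holds the higher of the two numbers, and its gap to compound 1 is beyond the usual scatter of such measurements. The two differ in two places at once, the group on the ring carbon and the group of seven heavy atoms, so neither change can be credited on its own.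

Compound 3, `CC1=C(C(=O)OCC2CC2)C(c2ccsc2)NC(=O)N1`, has not been measured. It keeps the ester of compound 2 and differs from it in one place: thiophen-3-yl in place of furan-2-yl on a saturated ring carbon. Going by the values given here, no measured pair shows this change alone, so its effect is unknown. Compound 1, which carries the same thiophen-3-yl, sits low, but it also carries a different seven-atom group. The step expected a number 9 percentage points lower from compound 2 to compound 3 (within the scatter) is a modest drop, possibly none beyond the scatter. Compound 3 is estimated to give 20%, within the range 3% to 40%.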

Compound 3, a percentage reported as inhibition, at one concentration (the size of the read-out at that concentration, not a potency): 39%
Compound 3: the middle estimate sits 19 percentage points below what was measured, within the range that was stated.
By their numbers in this assay, from the lowest: compound 1; then compounds 2 and 3 (each within the scatter of the next).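

In this assay, thiophen-3-yl in place of furan-2-yl on a saturated ring carbon gives a number 10 percentage points higher from compound 2 to compound 3 (within the scatter), so at this position the read-out does not separate these two five-membered aromatic rings, each with one hetero atom. Going by these compounds alone, with thiophen-3-yl held fixed, cyclopropylmethoxy in place of cyclopropyl on a carbonyl carbon gives a number 37 percentage points higher from compound 1 to compound 3 (beyond the scatter), which is the first view of that change on its own and ties the low number of compound 1 to the cyclopropyl group on the carbonyl carbon rather than to the thiophen-3-yl. No measurement is at hand that would explain either step.

The compounds shown leave open whether a phenyl ring on the saturated ring carbon, or an amine or a longer alkyl chain in place of cyclopropylmethoxy, would give a number in the same range. As far as these compounds go, each value is also a reading at a single concentration, so how the compounds compare in potency remains open.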